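Benzyloxy to cyclopropylmethoxy on a kynurenine monooxygenase inhibitor

The compounds below may be only part of what the source reports. "The series", "measured", "known", "first", "only" and "open" are said of these compounds alone.

The account concerns an assay on HEK293 cells for inhibition of kynurenine 3-monooxygenase (Homo sapiens), read by LC-MS, with a stated time of 20 h; on this read-out lower numbers stand for stronger inhibition and higher numbers for weaker inhibition. Of the compounds shown here, two have been measured. Compound 1 `O=C(O)CCn1c(=O)oc2cc(OCc3ccccc3)c(Cl)cc21` gives 1580 nM in this assay. Compound 2 `Cc1ccc([C@@H](C)Oc2cc3onc(CCC(=O)O)c3cc2Cl)nn1`, built on a different core, gives 3.16 nM in this assay. Of the two numbers, that of compound 1 is the higher one, and the gap to compound 2 lies beyond the usual scatter; as the two structures differ in more than one place, nothing more is drawn from that pair.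

Compound 3 `O=C(O)CCn1c(=O)oc2cc(OCC3CC3)c(Cl)cc21` has not yet been measured. It differs from compound 1 in a single place: cyclopropyl in place of phenyl on a saturated chain carbon bound to an oxygen on an aromatic ring.

Among the measured compounds shown here, no measured pair shows this change, so its effect is an open question. Because compound 1 sits at 1580 nM, the expectation is that compound 3 stays in the same region, with a modest rise in the number more likely than a fall, so the step of a 1.9-fold higher number from compound 1 to compound 3 (0.28 log units; within the scatter) is expected to be small. Compound 3 is estimated at 3000 nM in this assay, within a range from 1000 nM to 10000 nM.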

Compound 3, half-maximal inhibitory concentration: 1580 nM
Compound 3: the middle estimate sits 1.9-fold (0.28 log units) above what was measured; measured number inside the range.
By their numbers in this assay, from the lowest: compound 2; then compounds 1 and 3 (each within the scatter of the next).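

Read in this assay, the step of no change at the digits printed from compound 1 to compound 3 (within the scatter) is the first direct view of this position, as the earlier compounds offered no pair that differed in one place. On the core of compound 1, a six-membered aromatic ring of carbon only and a three-membered non-aromatic ring of carbon only give numbers that cannot be told apart when carried on the saturated chain carbon bound to an oxygen on an aromatic ring, so an aromatic ring at this place is not needed to hold the number in this region, and the smaller cyclopropyl serves as well as the phenyl on this one pair. Nothing in hand explains why the two compounds read alike.

Going by these compounds, whether any group at this place can move the number beyond the scatter remains open, since a single pair says nothing about a cyclohexyl ring, a longer alkyl chain or an amine carried on the same carbon. On these data alone, it also remains open whether the same exchange of phenyl for cyclopropyl would read the same way on the core of compound 2.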